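Lung stability notes on the amine substituent

A few compounds are considered here, and "the series" means these few. Any claim that something is new, unique, unknown or untested is made for them only; others in the source may bear on it.

Compound 1 `Cc1csc2cc([C@H](C)Nc3ncnc(N)c3C#N)c(-c3cccc(CN4CCC(CN(C)Cc5ccccn5)CC4)c3)c(=O)n12` is measured in an ADME assay on the whole organism (lung, Rattus norvegicus) for metabolic stability, read by LC-MS, with a stated time of 24 h (a lower number here means that less of the compound is left, a higher number that more of the compound is left), where compound 1 gives 5.2%. This is the highest of the three numbers, but it lies within the scatter of both companions. Compound 2 `Cc1csc2cc([C@H](C)Nc3ncnc(N)c3C#N)c(Cc3cccc(CN(C)CC(C)C)c3)c(=O)n12` gives 0%, and compound 3 `Cc1csc2cc([C@H](C)Nc3ncnc(N)c3C#N)c(Cc3cccc(CN(C)C)c3)c(=O)n12` gives 0%. Within the data shown here, the one measured step, no change at the digits printed from compound 2 to compound 3 (within the scatter), exchanges a group on a saturated chain carbon bound to an amine nitrogen and leaves the read-out unmoved. Compound 4 `Cc1csc2cc([C@H](C)Nc3ncnc(N)c3C#N)c(-c3cccc(CN4CCC(N(C)C)CC4)c3)c(=O)n12` is compound 1 with dimethylamino in place of (methyl((pyridin-2-yl)methyl)amino)methyl on a saturated ring carbon. This too touches only the amine-bearing part of the molecule, so the step from compound 2 to compound 3 is the nearest guide, though it concerns a different part and a smaller exchange. From that guide no shift beyond the scatter is expected, and compound 4 is expected at 4%, between 0% and 14%. The expected step, a number 1.2 percentage points lower from compound 1 to compound 4 (within the scatter), is estimated to stay within the scatter. Nothing among the three measured values points to a larger gain.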

Compound 4, percent of the compound remaining: 4.8%
Compound 4: the middle estimate sits 0.8 percentage points below what was measured; measured number inside the range.
By their numbers in this assay, from the lowest: compounds 2, 3, 4 and 1 (each within the scatter of the next).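

In this assay, dimethylamino in place of (methyl((pyridin-2-yl)methyl)amino)methyl on a saturated ring carbon gives a number 0.4 percentage points lower from compound 1 to compound 4 (within the scatter) and so cannot be told apart from compound 1 in this read-out. The earlier step concerned only a small group on a saturated chain carbon bound to an amine nitrogen, whereas this one shows that, on the six-membered non-aromatic ring, the one six-membered aromatic ring and the 10 heavy atoms of the leaving group can give way to 3 heavy atoms with no step beyond the scatter. No supporting measurement accounts for this result.

As far as these compounds go, what stays open is whether a non-amine group at this ring carbon, such as a hydroxyl or a carboxylic acid, would give a step beyond the scatter. From the compounds shown here alone, a primary amine or a morpholine ring at the same place is equally open.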